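Acetamido to cyclopropylamino on the shared core

A few compounds are considered here, and "the series" means these few. Any claim that something is new, unique, unknown or untested is made for them only; others in the source may bear on it.

Two compounds of this series have numbers in a functional assay on HCT-116 cells (Homo sapiens) for antiproliferative activity, read by MTT assay, with a stated time of 72 h (a lower number here means a stronger inhibitor, a higher number a weaker inhibitor), so far. Compound 1 `COc1c(NS(=O)(=O)c2ccc(F)cc2)cc(-c2ccc3nc(NC(C)=O)sc3c2)cc1C(N)=O` gives 1950 nM and stands lowest of the two; compound 2 `COc1c(NS(=O)(=O)c2ccc(F)cc2)cc(-c2ccc3nc(NC(=O)C4CC4)sc3n2)cc1C(N)=O` gives 2500 nM, within the scatter of compound 1, so no order between them is claimed. Compound 3 `COc1c(NS(=O)(=O)c2ccc(F)cc2)cc(-c2ccc3nc(NC4CC4)sc3c2)cc1C(N)=O` differs from compound 1 by cyclopropyl in place of acetyl on a nitrogen on an aromatic ring. Among the measured compounds shown here, no measured pair shows this exchange, so the step from compound 1 to compound 3 is expected to be small, likely not beyond the scatter, with a weaker result not excluded. For compound 3 the expected step is a 1.3-fold higher number from compound 1 to compound 3 (0.12 log units; within the scatter). Compound 3 is estimated at 2600 nM, between 900 nM and 8000 nM.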

Compound 3, half-maximal inhibitory concentration: > 50000 nM
Compound 3: a limit, no number; the forecaster's own chance of this, stated with the estimate: 5%; at least 19-fold (1.28 log units) between middle value and limit.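

In this assay, the nitrogen on an aromatic ring proves sensitive to what it carries: cyclopropyl in place of acetyl gives an at least 25-fold higher number from compound 1 to compound 3 (1.40 log units; beyond the scatter). Compound 1 and compound 2 both carry a carbonyl on this nitrogen, so neither spoke to its loss. For compound 3 the result is a limit and not a number, so the step has no upper bound: the limit of > 50000 nM in this assay, at which 1 of the 3 values shown sits.

The compounds shown do not separate the loss of acetyl from the arrival of cyclopropyl. A free amine or a methyl group on this nitrogen would bear on that question.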